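The compounds below may be only part of what the source reports. "The series", "measured", "known", "first", "only" and "open" are said of these compounds alone.

Compound 1 `CC(C)(C)CN1CCc2c(cccc2Oc2ncccc2NC(=O)Nc2ccc(OC(F)(F)F)cc2)C1` and compound 2 `CCCN1CCc2c(cccc2Oc2ncccc2NC(=O)Nc2ccc(OC(F)(F)F)cc2)C1` share one core and differ only in the group carried on the ring nitrogen. In an assay on HEK293 cells for displacement of a labelled ligand from P2Y purinoceptor 1 (Homo sapiens), read by scintillation counting, with a stated time of 1 h (a higher number here means a weaker inhibitor, a lower number a stronger inhibitor), compound 1 gives 11 nM, while compound 2 gives 620 nM. Compound 2 thus stands as the higher, weaker of the two measured numbers, and the step of a 56-fold higher number from compound 1 to compound 2 (1.75 log units; beyond the scatter) shows how much was lost when the larger group was cut down. Compound 3 `CCN1CCc2c(cccc2Oc2ncccc2NC(=O)Nc2ccc(OC(F)(F)F)cc2)C1` takes this same direction one stage further: hydrogen in place of methyl on a saturated chain carbon, two bonds along the chain from an amine nitrogen in a ring. Going by the values given here, only the step from compound 1 to compound 2 bears on this change, and it was large; since the new cut removes less than that one did, a smaller rise is expected in this assay, again toward a weaker inhibitor. Compound 3 is therefore estimated at 1500 nM, within 500 nM to 5000 nM, an expected step of a 2.4-fold higher number from compound 2 to compound 3 (0.38 log units; beyond the scatter).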

Compound 3, inhibition constant: 1700 nM
Compound 3: middle estimate off by 1.1-fold (0.05 log units), on the low side, within the range that was stated.
By their numbers in this assay, from the lowest: compound 1; then compound 2; then compound 3.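

Cutting one more carbon from the chain moves the number the same way again in this assay (a 2.7-fold higher number from compound 2 to compound 3 (0.44 log units; beyond the scatter)), so all three compounds now fall in one order, with none going against it: the shorter the chain on the ring nitrogen, the weaker the inhibitor. This step is much smaller than the first one (a 56-fold higher number from compound 1 to compound 2 (1.75 log units; beyond the scatter)), and the whole change of methyl in place of tert-butyl adds up to a large loss (a 150-fold higher number from compound 1 to compound 3 (2.19 log units; beyond the scatter)), most of it in that first step. Nothing available here explains why the number rises as the group shrinks.

On these data alone, it remains open whether the low number of compound 1 depends on the branched tert-butyl or simply on more carbons, which an unbranched butyl chain in its place would test. A ring such as cyclohexyl on that chain is also untested in the compounds shown.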